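A few compounds are considered here, and "the series" means these few. Any claim that something is new, unique, unknown or untested is made for them only; others in the source may bear on it.

This account follows the change from compound 1 `Cc1nc(-c2cc3ccccc3o2)sc1COc1ccc2c(c1)OCC2CC(=O)O` to compound 4 `Cc1nc(-c2ccc(F)cc2)sc1COc1ccc2c(c1)OCC2CC(=O)O` in a functional assay on CHO cells for agonist activity at Free fatty acid receptor 1 (Homo sapiens), read by FLIPR and calcium flux; on this read-out lower numbers stand for an effect already at smaller amounts and higher numbers for an effect only at larger amounts of compound. On the numbers in hand, compound 1 stands on no single value: in this assay compound 1 is recorded as "not determined" (no result reported), and compound 2 `Cc1nc(-c2cccc3ccccc23)sc1COc1ccc2c(c1)OCC2CC(=O)O`, which likewise carries a fused two-ring group on the shared core, is in the same position, since in this assay compound 2 is recorded as "not determined" (no result reported). Among the measured compounds shown here, the one measured anchor is compound 3 `Cc1nc(-c2ccc(Cl)cc2)sc1COc1ccc2c(c1)OCC2CC(=O)O`, which in this assay gives 85.6 nM.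

The change from compound 1 to compound 4 is this: 4-fluorophenyl in place of 1-benzofuran-2-yl on an aromatic carbon.

With no number for compound 1, no size or direction of the step to compound 4 in this assay can be set against a measured starting point, and none is claimed. What the data do allow is a comparison with compound 3: compound 3 and compound 4 share the same core and differ only in the halogen on the phenyl group, chlorine in compound 3 and fluorine in compound 4. The value of compound 3, 85.6 nM, is therefore the sole basis for an expectation. Compound 4 is expected to come out near 130 nM, in a range from 40 nM to 450 nM, with the fluorine analog estimated to sit close to or somewhat weaker than its chlorine counterpart.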

Compound 4, half-maximal effective concentration: 48.7 nM
Beside the measured number, compound 4's estimate is 2.7-fold (0.43 log units) above it; the measured number falls inside the stated range.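

In this assay, exchanging the halogen on the phenyl group gives a 1.8-fold lower number from compound 3 to compound 4 (0.24 log units; within the scatter), so at this aromatic carbon, on the five-membered aromatic ring with 1 nitrogen and 1 sulfur, 4-fluorophenyl and its chlorine counterpart cannot be told apart on these numbers, and the result now rests on two measured compounds rather than one. The step from compound 1 to compound 4 cannot be read, and with compound 2 also lacking a number, the fused two-ring groups at this position remain uncompared with either halogen-bearing phenyl group. No measured information is available that explains the outcome of the halogen exchange.

The compounds shown leave open whether the phenyl group at this position needs a halogen at all, since neither plain phenyl nor a phenyl group carrying an amine, a methoxy group or a nitrile in place of the fluorine appears among them. They also leave open how a group with a different ring, such as pyridine, would compare with 4-fluorophenyl on the shared core in this assay.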